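A few compounds are considered here, and "the series" means these few. Any claim that something is new, unique, unknown or untested is made for them only; others in the source may bear on it.

The three measured compounds share one core and differ only in the group on the carbonyl carbon whose other neighbour is an amide-type nitrogen in a ring. Compound 1 `O=C(CC1CCCCC1)N1CCN(c2nc(=O)c3cc(C(F)(F)F)cc([N+](=O)[O-])c3s2)CC1` carries a cyclohexylmethyl group there, and in a physicochemical assay for solubility, read by HPLC (a lower number here means a less soluble compound, a higher number a more soluble compound), compound 1 gives 0.12 ug/mL. Compound 2 `O=C(c1ccc(Cl)cc1)N1CCN(c2nc(=O)c3cc(C(F)(F)F)cc([N+](=O)[O-])c3s2)CC1` carries a 4-chlorophenyl group, and in this assay compound 2 gives 5.19 ug/mL. Compound 3 `O=C(C1CC1)N1CCN(c2nc(=O)c3cc(C(F)(F)F)cc([N+](=O)[O-])c3s2)CC1` carries a cyclopropyl group, and in this assay compound 3 gives 52.9 ug/mL, the highest of the three numbers, as shown by a 440-fold higher number from compound 1 to compound 3 (2.64 log units; beyond the scatter) and by a 10-fold higher number from compound 2 to compound 3 (1.01 log units; beyond the scatter).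

Compound 4 `O=C(c1cccc(F)c1)N1CCN(c2nc(=O)c3cc(C(F)(F)F)cc([N+](=O)[O-])c3s2)CC1` is the unmeasured compound: 3-fluorophenyl in place of cyclopropyl on a carbonyl carbon. The step that bears most directly on it is a 10-fold higher number from compound 2 to compound 3 (1.01 log units; beyond the scatter), since compound 2 also carries an aromatic ring on that carbonyl carbon, while a 43-fold higher number from compound 1 to compound 2 (1.64 log units; beyond the scatter) shows that an aromatic ring there still stands well above the cyclohexylmethyl case. The step from compound 3 to compound 4 is therefore expected to be a large one downward, roughly reversing the cyclopropyl step, as a 6.6-fold lower number from compound 3 to compound 4 (0.82 log units; beyond the scatter). The estimated value for compound 4 is 8 ug/mL, with a range from 2.5 ug/mL to 25 ug/mL.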

Compound 4, solubility: 0.2 ug/mL
The estimate for compound 4 lay 40-fold (1.60 log units) above the measured number, outside the stated range (below it).
By their numbers in this assay, from the lowest: compounds 1 and 4 (each within the scatter of the next); then compound 2; then compound 3.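

In this assay an aromatic ring on the carbonyl carbon does not by itself fix the number: a 26-fold lower number from compound 2 to compound 4 (1.41 log units; beyond the scatter) when 3-fluorophenyl replaces 4-chlorophenyl, so these two aromatic groups do not read alike at this place. Replacing cyclopropyl with 3-fluorophenyl gives a 260-fold lower number from compound 3 to compound 4 (2.42 log units; beyond the scatter) and so spans nearly the whole measured range, while the comparison with cyclohexylmethyl gives a 1.7-fold higher number from compound 1 to compound 4 (0.22 log units; within the scatter) and leaves compound 1 and compound 4 within the scatter of each other, although only compound 4 carries an aromatic ring. Nothing available here accounts for the gap between the two aromatic groups.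

A plain phenyl or a 4-fluorophenyl group would show whether the halogen's identity or its placement carries that gap. On these data alone, how a group bearing an amine or a carboxylic acid would read in this assay at this carbonyl carbon stays open.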